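The compounds below may be only part of what the source reports. "The series", "measured", "known", "first", "only" and "open" are said of these compounds alone.

Compound 1 `O=C(CCCCC1CCSS1)NCc1cn(CCCOc2ccc3cc(-c4ccc(Br)cc4)c(=O)oc3c2)nn1` gives 63.3% in a functional assay on PC-12 cells (Rattus norvegicus) for cytotoxicity, read by MTT assay, with stated times of 3 h and 2 h, tested at 10 uM; on this read-out higher numbers stand for a stronger effect at the one concentration tested and lower numbers for a weaker effect.
Compound 2 `O=C(CCCCC1CCSS1)NCc1cn(CCCCOc2ccc3ccc(=O)oc3c2)nn1` gives 65.1% in this assay.
Compound 3 `COc1ccc(-c2cc3ccc(OCCCCn4cc(CNC(=O)CCCCC5CCSS5)nn4)cc3oc2=O)cc1` gives 48.6% in this assay.

Among these three, compound 3 stands lowest, beyond the scatter from both of the others. Going by the values given here, the only single-place step measured is a number 16.5 percentage points lower from compound 2 to compound 3 (beyond the scatter), which placed 4-methoxyphenyl on an aromatic carbon. Compound 4 `O=C(CCCCC1CCSS1)NCc1cn(CCCCOc2ccc3cc(-c4ccc(Cl)cc4)c(=O)oc3c2)nn1` carries instead (chloro in place of methoxy on an aromatic carbon). Among the compounds with values here, no measured pair sets chloro directly against methoxy. Within the data shown here, compound 4 and compound 1 both carry a halogen-bearing phenyl, yet they differ in several places, so no single step joins them. Compound 1 gives 63.3%, a number that sits with compound 2 rather than with compound 3; this is a hint, not a measured step. An upward step is therefore expected, a number 9.4 percentage points higher from compound 3 to compound 4 (within the scatter), of a size near the edge of the scatter. Compound 4 is estimated at 58% in this assay, with a range from 46% to 70%.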

Compound 4, a percentage reported as activity, at one concentration (the size of the read-out at that concentration, not a potency): 61.8%
Beside the measured number, compound 4's estimate is 3.8 percentage points below it; low and high end bracket the measured number.
By their numbers in this assay, from the lowest: compound 3; then compounds 4, 1 and 2 (each within the scatter of the next).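

Exchanging methoxy for chloro on the aromatic carbon para to a large group gives a number 13.2 percentage points higher from compound 3 to compound 4 (beyond the scatter), so in this assay the outcome at this position depends on the substituent carried by the phenyl ring. Compared with the unsubstituted core, the 4-chlorophenyl group gives a number 3.3 percentage points lower from compound 2 to compound 4 (within the scatter), whereas the 4-methoxyphenyl group gave a number 16.5 percentage points lower from compound 2 to compound 3 (beyond the scatter), so adding a phenyl ring at this place does not by itself bring the number down. No measurement shown here accounts for the difference between chloro and methoxy.

Going by these compounds, it remains open how an amine, a hydroxyl or a carboxylic acid at the same place on the phenyl ring would read. Compound 1 differs from compound 4 in more than one place, so the separate contributions of its bromo group and its linker remain unresolved.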